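A few compounds are considered here, and "the series" means these few. Any claim that something is new, unique, unknown or untested is made for them only; others in the source may bear on it.

Measured in a functional assay on A549 cells (Homo sapiens) for cytotoxicity, read by MTT assay, with a stated time of 24 h, tested at 40 uM; a lower number here means a stronger effect, a higher number a weaker effect of the compound at the concentration tested:
compound 1 `CCOC(=O)CCC(=O)N1CCN(CCCOc2cc3c(Nc4ccc(F)c(Cl)c4)ncnc3cc2OC)CC1` gives 67.4%;
compound 2 `CCCOC(=O)CCC(=O)N1CCN(CCCOc2cc3c(Nc4ccc(F)c(Cl)c4)ncnc3cc2OC)CC1` gives 80.9%;
compound 3 `CCCCCCCCCCOC(=O)CCC(=O)N1CCN(CCCOc2cc3c(Nc4ccc(F)c(Cl)c4)ncnc3cc2OC)CC1` gives 15.5%.

Compound 3 stands lowest of the three in this assay; the nearest is compound 1, the furthest compound 2, the gaps being a number 51.9 percentage points lower from compound 1 to compound 3 (beyond the scatter) and a number 65.4 percentage points lower from compound 2 to compound 3 (beyond the scatter). Compound 4 `CCCCCCCCCCCOC(=O)CCC(=O)N1CCN(CCCOc2cc3c(Nc4ccc(F)c(Cl)c4)ncnc3cc2OC)CC1` differs from compound 3 by methyl in place of hydrogen on a saturated chain carbon, ten or more bonds along the chain from an oxygen next to a carbonyl group.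

For the measured compounds named here, the steps that bear on this are the two chain extensions, a number 51.9 percentage points lower from compound 1 to compound 3 (beyond the scatter) and a number 65.4 percentage points lower from compound 2 to compound 3 (beyond the scatter), both large and downward, while the single-carbon step a number 13.5 percentage points higher from compound 1 to compound 2 (beyond the scatter) went modestly the other way. One further methyl on an already long chain is expected to move the number only a little, if at all, downward. For compound 4 the estimate is 12%, range 3% to 25%, corresponding to an expected step of a number 3.5 percentage points lower from compound 3 to compound 4 (within the scatter).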

Compound 4, a percentage reported as activity, at one concentration (the size of the read-out at that concentration, not a potency): 12%
Estimate against measurement, compound 4: no gap at the digits printed; measured number inside the range.
By their numbers in this assay, from the lowest: compounds 4 and 3 (each within the scatter of the next); then compound 1; then compound 2.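

In this assay, a methyl added at this far end of the chain gives a number 3.5 percentage points lower from compound 3 to compound 4 (within the scatter), so the same change that moved the number on the short chain does not move it here: the same change on two cores in this assay, a number 13.5 percentage points higher (beyond the scatter) from compound 1 to compound 2 and a number 3.5 percentage points lower (within the scatter) from compound 3 to compound 4, 17 percentage points apart, beyond the scatter of two such steps

The long chains stay well apart from the short ones, with a number 68.9 percentage points lower from compound 2 to compound 4 (beyond the scatter) and a number 55.4 percentage points lower from compound 1 to compound 4 (beyond the scatter), and the drop differs with the pair compared: the same change on two cores in this assay, a number 51.9 percentage points lower (beyond the scatter) from compound 1 to compound 3 and a number 68.9 percentage points lower (beyond the scatter) from compound 2 to compound 4, 17 percentage points apart, beyond the scatter of two such steps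

Chains of intermediate length leave open where between compound 2 and compound 3 the number falls. Also open, from the compounds shown here alone, is whether a longer chain, or a carboxylic acid or an amine at the chain end, would hold it there.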